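The source may report more compounds than this note shows. Statements on the series, on what has been measured and on what is new or still open speak of the compounds shown alone.

Measured in an ADME assay for pharmacokinetics, read by LC-MS, in phosphate buffer, with a stated time of 120 min, at pH 7.4, tested at 1 uM, in the presence of a further agent that is not named here; a higher number here means that the compound lasts longer, a lower number that the compound disappears faster:
Compound 1 `CN(C)CC/C=C/C(=O)Nc1ccccc1`: 7.38 h
Compound 2 `C/C=C/C(=O)Nc1ccccc1`: > 8.53 h (a limit)
Compound 3 `O=C(/C=C/CF)Nc1ccccc1`: > 8.53 h (a limit)

Compound 3 sits at the limit of > 8.53 h in this assay, at which 2 of the 3 values shown sit, so it has a limit and not a number. The change to compound 4 `CCN(CC)C/C=C/C(=O)Nc1ccccc1` is diethylamino in place of fluoro on a saturated chain carbon bound to a double-bonded chain carbon, with diethylamino in place of fluoro on a saturated chain carbon bound to a double-bonded chain carbon. The closest measured change is an at least 1.1-fold higher number from compound 1 to compound 3 (0.06 log units; that floor lies within the scatter), and the one to the unsubstituted chain is an at least 1.1-fold higher number from compound 1 to compound 2 (0.06 log units; that floor lies within the scatter). Both floors stay within the scatter, and a step that the two limits leave unreadable from compound 2 to compound 3. Compound 1, which carries an amine, reads 7.38 h, so only a modest drop is expected in this assay. The expected size is an at least 1.4-fold lower number from compound 3 to compound 4 (0.15 log units; that floor lies within the scatter). For compound 4 the estimate is 6 h, with an expected range of 2.5 h to 10 h.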

Compound 4, half-life: 2.83 h
For compound 4 the middle estimate is 2.1-fold (0.33 log units) above the measured one, and the stated range covers the measured number.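

In this assay, for the compounds shown here, diethylamino on a saturated chain carbon bound to a double-bonded chain carbon gives an at least 3.0-fold lower number from compound 3 to compound 4 (0.47 log units; beyond the scatter) and an at least 3.0-fold lower number from compound 2 to compound 4 (0.47 log units; beyond the scatter) as the first steps at this position beyond the scatter. Two amine-bearing groups also part here, with a 2.6-fold lower number from compound 1 to compound 4 (0.42 log units; beyond the scatter) as a step likewise beyond the scatter. The first two steps are only floors because compounds 2 and 3 each stand at a limit of the assay: the limit of > 8.53 h in this assay, at which 2 of the 4 values shown sit.

The step from compound 2 to compound 3 cannot be read. The compounds shown leave open how a cyclic amine such as morpholine or piperidine would behave at this place.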